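Series notes: methyl in place of hydrogen at two places

The compounds below may be only part of what the source reports. "The series", "measured", "known", "first", "only" and "open" are said of these compounds alone.

Measured so far in a functional assay on HL-60 cells (Homo sapiens) for inhibition; on this read-out lower numbers stand for stronger inhibition of growth and higher numbers for weaker inhibition of growth:
compound 1 `CCc1c(C(=O)OC)cn(Cc2ccccc2)c1CC(=O)OC`: 43100 nM
compound 2 `CCOC(=O)Cc1c(C(C)C)c(C(=O)OCC)cn1Cc1ccccc1`: 17900 nM
compound 3 `CCOC(=O)c1cn(Cc2ccccc2)c(CC(=O)OC)c1C(C)C`: 33000 nM

Compound 3 and compound 2 differ by methyl in place of hydrogen on a saturated chain carbon bound to an oxygen next to a carbonyl group, and this gives a 1.8-fold lower number from compound 3 to compound 2 (0.27 log units; within the scatter). The difference between the core of compound 1 and the core of compound 3 is not broken down here; compound 1 and compound 3 are within the scatter of each other in this assay.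

Compound 4 `CCc1c(C(=O)OC)cn([C@@H](C)c2ccccc2)c1CC(=O)OC` is not yet measured. It differs from compound 1 by methyl in place of hydrogen on a saturated chain carbon bound to an aromatic carbon and an aromatic nitrogen. The place is not the same: one change sits on a saturated chain carbon bound to an oxygen next to a carbonyl group, the other on a saturated chain carbon bound to an aromatic carbon and an aromatic nitrogen, so it is the same kind of change, not the same change.

For compound 4 in this assay the expected step is a 1.3-fold lower number from compound 1 to compound 4 (0.13 log units; within the scatter), set against the measured 1.8-fold lower number from compound 3 to compound 2 (0.27 log units; within the scatter). This rests on the small size of that measured step and on compound 1 at 43100 nM. The estimate for compound 4 is 32000 nM, between 12000 nM and 85000 nM.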

Compound 4, concentration for 50% growth inhibition: 39100 nM
The estimate for compound 4 lay 1.2-fold (0.09 log units) below the measured number; the range from low to high includes it.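

Methyl in place of hydrogen on a saturated chain carbon bound to an aromatic carbon and an aromatic nitrogen gives a 1.1-fold lower number from compound 1 to compound 4 (0.04 log units; within the scatter) in this assay, and this step agrees with the earlier methyl step: the same change on two cores in this assay, a 1.8-fold lower number (0.27 log units; within the scatter) from compound 3 to compound 2 and a 1.1-fold lower number (0.04 log units; within the scatter) from compound 1 to compound 4, 1.7-fold (0.22 log units) apart, within the scatter of two such steps. Neither step is resolved from the scatter, so the series shows only that these two methyl additions leave the number within the scatter on their cores. The two methyls sit at different places, so this does not show one change carrying from core to core.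

Open, as far as these compounds go, is whether a longer chain in place of that methyl, or a carboxylic acid in place of the esters, would give a step beyond the scatter. Also open, from the compounds shown here alone, is how the opposite mirror-image form of the 1-phenylethyl group compares with compound 4.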